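Notes on the step from compound 3 to compound 4

The source may hold more compounds than are shown below. What is called first, only, known or untested is meant among the compounds shown, and "the series" means these compounds.

In a functional assay on HepG2 cells (Homo sapiens) for cytotoxicity, read by MTT assay (on this read-out lower numbers stand for stronger inhibition and higher numbers for weaker inhibition), compound 1 `C=C1C(=O)[C@]23C[C@@]1(O)CC[C@H]2[C@@]12C=CC(=O)[C@](C)(C(=O)O1)[C@H]2[C@@H]3C(=O)OC` gives 37200 nM while compound 2 `C=C1C(=O)[C@]23C[C@@]1(F)CC[C@H]2[C@@]12C=CC(=O)[C@](C)(C(=O)O1)[C@H]2[C@@H]3C(=O)OC` gives 40600 nM and compound 3 `C=C1C(=O)[C@]23C[C@@]1(F)CC[C@H]2[C@@]12C=CC(=O)[C@](C)(C(=O)O1)[C@H]2[C@@H]3C(=O)OCc1ccccc1` gives 44100 nM as its number. Compound 3 therefore stands level with the other two, all three values lying within the scatter of one another.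

Compound 4 `C=C1C(=O)[C@]23C[C@@]1(OCC)CC[C@H]2[C@@]12C=CC(=O)[C@](C)(C(=O)O1)[C@H]2[C@@H]3C(=O)OCc1ccccc1` differs from compound 3 by ethoxy in place of fluoro on a saturated ring carbon. Going by the values given here, two measured steps bear on this. The change at the same ring carbon gave a 1.1-fold higher number from compound 1 to compound 2 (0.04 log units; within the scatter) as its result, and the change in the ester gave a 1.1-fold higher number from compound 2 to compound 3 (0.04 log units; within the scatter) as its result. Both are small, but neither involves ethoxy, which has no measurement in this series.

Expected in this assay is no step beyond the scatter, in neither direction, with the estimate standing for a 1.1-fold lower number from compound 3 to compound 4 (0.04 log units; within the scatter) and no more. Compound 4 is expected at 40000 nM within an estimated range of 18000 nM to 80000 nM on present evidence.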

Compound 4, half-maximal inhibitory concentration: 29600 nM
Compound 4: the middle estimate sits 1.4-fold (0.13 log units) above what was measured, within the range that was stated.
By their numbers in this assay, from the lowest: compounds 4, 1, 2 and 3 (each within the scatter of the next).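

At this saturated ring carbon of the five-membered ring, ethoxy in place of fluoro gives a 1.5-fold lower number from compound 3 to compound 4 (0.17 log units; within the scatter) in this assay. Hydroxy and fluoro were the only groups compared at this carbon before, so compound 4 adds a first group carrying a carbon chain there, and the number still does not move beyond the scatter. Nothing measured here offers an explanation for this result.

From the compounds shown here alone, whether an amine, a carboxylic acid or a longer chain at this ring carbon would produce a step beyond the scatter remains open. Also open, going by these compounds, is whether ethoxy gives a similar step when paired with the ester of compound 1, as compound 4 has a one-place comparison only with compound 3.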